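This account rests on a few compounds, and the source may have more. Where it says the series, first, only, none or still open, it means among the compounds named here.

Measured so far in a functional assay on MIA PaCa-2 cells (Homo sapiens) for inhibition, read by MTT assay, with a stated time of 72 h; a lower number here means a stronger inhibitor of growth, a higher number a weaker inhibitor of growth:
compound 1, `Cc1ccc(C)c(S(=O)(=O)NCCCCCCNCc2ccc(Br)cc2)c1`, gives 12000 nM
compound 2, `O=S(=O)(NCCCNCc1ccc(Cl)cc1)c1cc(C(F)(F)F)cc(C(F)(F)F)c1`, gives 2800 nM
compound 3, `O=S(=O)(NCCCNCc1ccc(C(F)(F)F)cc1)c1cc(C(F)(F)F)cc(C(F)(F)F)c1`, gives 2500 nM

Compound 1 stands at the highest of the three numbers; compound 2 and compound 3 both sit at lower numbers, beyond the scatter from compound 1, while the values of compound 2 and compound 3 lie within the scatter of each other.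

Compound 4, `O=S(=O)(NCCCCCCNCc1ccc(Br)cc1)c1ccc2ccsc2c1`, is yet to be measured. The change from compound 1: 1-benzothiophen-6-yl in place of 2,5-dimethylphenyl on a sulfonyl sulfur. Going by the values given here, the one measured step, a 1.1-fold lower number from compound 2 to compound 3 (0.05 log units; within the scatter), concerns the benzylamine end of the molecule and was within the scatter; it says nothing about a change at the sulfonyl sulfur. Among the compounds with values here, compound 2 and compound 3 differ from compound 1 in more than one place, so no single step can be drawn from them either. Within the data shown here, no measured step therefore informs this change, and the expectation for compound 4 is a number not far from that of compound 1, with wide uncertainty in either direction. On that basis the expected step is a 1.5-fold lower number from compound 1 to compound 4 (0.18 log units; within the scatter). Compound 4 is estimated at 8000 nM, within 2500 nM to 25000 nM.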

Compound 4, concentration for 50% growth inhibition: 6000 nM
Beside the measured number, compound 4's estimate is 1.3-fold (0.12 log units) above it; the measured number falls inside the stated range.
By their numbers in this assay, from the lowest: compounds 3 and 2 (each within the scatter of the next); then compounds 4 and 1 (each within the scatter of the next).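

In this assay, the first change read at the sulfonyl sulfur is a 2.0-fold lower number from compound 1 to compound 4 (0.30 log units; within the scatter). With the rest of the molecule unchanged, 1-benzothiophen-6-yl can therefore stand in place of 2,5-dimethylphenyl on this sulfur without a change beyond the scatter, even though it adds a five-membered aromatic ring with a sulfur atom. No measurement here gives a cause for the size of this step.

On these data alone, compound 2 and compound 3 differ from compound 4 in more than one place, so how far their lower numbers depend on the group on the sulfonyl sulfur remains open. Also open, as far as these compounds go, is whether a naphthyl group, or a phenyl ring carrying a carboxylic acid or an amine, would move the number beyond the scatter at this position.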